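The source may hold more compounds than are shown below. What is called first, only, known or untested is meant among the compounds shown, and "the series" means these compounds.

Measured so far: compound 1 `CN(C)CCCCCSC1=Nc2ccccc2C(CC(=O)NCc2ccccc2)N1c1ccc(-c2ccc(F)cc2)cc1` gives 250 nM in an assay on cells for inhibition of Voltage-dependent T-type calcium channel subunit alpha-1G (Homo sapiens), read by patch clamp; a higher number here means a weaker inhibitor, a lower number a stronger inhibitor; compound 2 `O=C(CC1c2ccccc2N=C(SCCCCCN2CCCC2)N1c1ccc(-c2ccccc2)cc1)NCc1ccc(F)cc1` gives 15000 nM; compound 3 `CN(C)CCCCCSC1=Nc2ccccc2C(CC(=O)NCc2ccccc2)N1c1ccc(-c2ccccc2)cc1` gives 7770 nM.

Compound 2 carries the highest number of the three; its gap to compound 3 lies within the scatter, its gap to compound 1 lies beyond it. Compound 4 `O=C(CC1c2ccccc2N=C(SCCCCCN2CCCC2)N1c1ccc(-c2ccc(F)cc2)cc1)NCc1ccc(F)cc1` differs from compound 2 by fluoro in place of hydrogen on an aromatic carbon. For the measured compounds named here, the only measured step that bears on this change is its reverse at the same aromatic carbon, a 31-fold higher number from compound 1 to compound 3 (1.49 log units; beyond the scatter). Running that change backwards, a step of comparable size toward a lower number is expected in this assay for compound 4. The estimate for compound 4 is therefore 600 nM, with a range from 150 nM to 2500 nM. This expected step, a 25-fold lower number from compound 2 to compound 4 (1.40 log units; beyond the scatter), rests on one pair only, compound 1 and compound 3.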

Compound 4, half-maximal inhibitory concentration: 12600 nM
For compound 4 the middle estimate is 21-fold (1.32 log units) below the measured one; the whole stated range lies below it.
By their numbers in this assay, from the lowest: compound 1; then compounds 3, 4 and 2 (each within the scatter of the next).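

Phenyl to 4-fluorophenyl gives a 1.2-fold lower number from compound 2 to compound 4 (0.08 log units; within the scatter) in this assay and so does not repeat on the core of compound 2 what it did on the core of compound 1. The outcome of this change at this position depends on the core: the same change on two cores in this assay, a 31-fold higher number (1.49 log units; beyond the scatter) from compound 1 to compound 3 and a 1.2-fold higher number (0.08 log units; within the scatter) from compound 4 to compound 2, 26-fold (1.42 log units) apart, beyond the scatter of two such steps

The two cores differ in both the terminal amine and the benzyl amide, and the compounds shown do not separate these two places. From the compounds shown here alone, whether chloro or methoxy on the same aromatic carbon would follow fluoro on either core also stays open.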